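The compounds below may be only part of what the source reports. "The series", "measured", "known", "first", "only" and "open" are said of these compounds alone.

Measured compounds:
compound 1, `Cc1c(Sc2ccc(Cl)cc2)c(=O)on1C(=O)N1CCCCC1`: 6 nM
compound 2, `Cc1c(S(=O)(=O)c2ccc(Cl)cc2)c(=O)on1C(=O)N1CCCCC1`: 35 nM
compound 3, `Cc1c(C)n(C(=O)N2CCCCC2)oc1=O`: 13 nM

All three numbers come from an assay (strain Wistar) for inhibition of Hormone-sensitive lipase (Rattus norvegicus), read by spectrophotometry; a higher number here means a weaker inhibitor, a lower number a stronger inhibitor. Among them, compound 3 stands second highest of the three. Its nearest neighbour is compound 1, whose number is lower by a gap beyond the usual scatter of repeated measurements; compound 2 lies furthest from it, with a higher number, again beyond the scatter. For the measured compounds named here, no pair of measured compounds differs in a single place, so nothing in these three shows directly how a small change on the core of compound 3 moves the read-out.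

Compound 4, `CCc1c(C)n(C(=O)N2CCCCC2)oc1=O`, differs from compound 3 in one place: methyl in place of hydrogen on a saturated chain carbon bound to an aromatic carbon. Going by the values given here, this is a small change, and with no comparable step among the measured compounds the expectation is a step of no change at the digits printed from compound 3 to compound 4 (within the scatter) in this assay, which amounts to none beyond the scatter. Compound 4 is therefore estimated at 13 nM, with a range from 5 nM to 35 nM.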

Compound 4, half-maximal inhibitory concentration: 18 nM
Beside the measured number, compound 4's estimate is 1.4-fold (0.14 log units) below it, and the stated range covers the measured number.
By their numbers in this assay, from the lowest: compound 1; then compounds 3, 4 and 2 (each within the scatter of the next, the first and the last beyond it).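

For the compounds shown here, the step from methyl to ethyl is the first comparison in this set between two compounds that differ in a single place, and in this assay it reads a 1.4-fold higher number from compound 3 to compound 4 (0.14 log units; within the scatter) for one added methyl. Going by these compounds alone, on a saturated chain carbon bound to an aromatic carbon, this small extension therefore does not separate the two compounds, something the earlier compounds could not show. Nothing given here offers a measured reason for this result.

From the compounds shown here alone, whether a longer chain such as propyl, a phenyl ring, an amine or a carboxylic acid at this place would also stay within the scatter of compound 3 remains open. The compounds shown also leave open whether the same step would read alike on the core of compound 1 or compound 2.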